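A few compounds are considered here, and "the series" means these few. Any claim that something is new, unique, unknown or untested is made for them only; others in the source may bear on it.

In an in vitro ADME assay on microsomes from Gut (Homo sapiens) for metabolic stability, in the presence of a further agent that is not named here (a lower number here means slower removal, a higher number faster removal of the compound), compound 1 `CC(C)(CO)CNC(=O)c1cc2cc(C#N)ccc2n1Cc1cc(Cl)cc(Cl)c1` gives 98 mL.min-1.g-1 and compound 2 `COc1ccc(Br)cc1Cn1c(C(=O)NCC(C)(C)CO)cc2cc(C#N)ccc21` gives 94 mL.min-1.g-1, so the two stand within the scatter of each other. Compound 3 `Cc1ccc(Cl)cc1Cn1c(C(=O)NCC(C)(C)CO)cc2cc(C#N)ccc21` has not yet been measured, and it differs from compound 1 as follows: 5-chloro-2-methylphenyl in place of 3,5-dichlorophenyl on a saturated chain carbon bound to an aromatic nitrogen. Among the measured compounds shown here, the one measured step that bears on this change is a 1.0-fold lower number from compound 1 to compound 2 (0.02 log units; within the scatter), made at the same place and within the scatter. No change beyond the scatter is therefore expected in this assay, and the expected step is a 1.1-fold lower number from compound 1 to compound 3 (0.03 log units; within the scatter). Compound 3 is estimated at 92 mL.min-1.g-1, with an expected range of 50 mL.min-1.g-1 to 165 mL.min-1.g-1.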

Compound 3, intrinsic clearance in microsomes: 124 mL.min-1.g-1
Compound 3: middle estimate off by 1.3-fold (0.13 log units), on the low side; measured number inside the range.
By their numbers in this assay, from the lowest: compounds 2, 1 and 3 (each within the scatter of the next).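

In this assay, a third substituted phenyl group at this place, on a saturated chain carbon bound to an aromatic nitrogen, again leaves the number within the scatter: the result is a 1.3-fold higher number from compound 1 to compound 3 (0.10 log units; within the scatter) and a 1.3-fold higher number from compound 2 to compound 3 (0.12 log units; within the scatter) here. So 3,5-dichlorophenyl, 5-bromo-2-methoxyphenyl and 5-chloro-2-methylphenyl cannot be told apart in this read-out. Nothing available explains this level of clearance. Still open, from the compounds shown here alone, is whether a basic amine or a carboxylic acid on this ring would shift the number beyond the scatter. Equally open, going by these compounds, is what a pyridine ring in place of the phenyl ring would do.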